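Adding a second chloro to the fused core of compound 1

A few compounds are considered here, and "the series" means these few. Any claim that something is new, unique, unknown or untested is made for them only; others in the source may bear on it.

Compound 1 `ClCc1cccc(Cn2cnc3ncnc(Cl)c32)c1` is the strongest of the three measured compounds in a functional assay on 786-0 cells (Homo sapiens) for cytotoxicity, read by sulforhodamine B assay, with a stated time of 48 h (on this read-out lower numbers stand for stronger inhibition of growth and higher numbers for weaker inhibition of growth), where compound 1 gives 2040 nM. Compound 2 `ClCc1cccc(Cn2cnc3c(Cl)nc(Cl)nc32)c1` gives 12300 nM and compound 3 `ClCc1ccc(Cn2cnc3c(Cl)nc(Cl)nc32)cc1` gives 14100 nM, both well beyond the scatter from compound 1. Compound 4 `ClCc1cccc(Cn2cnc3nc(Cl)nc(Cl)c32)c1` differs from compound 1 by chloro in place of hydrogen on an aromatic carbon, placing the chloro between two ring nitrogen atoms of the fused core. Among the measured compounds shown here, no measured pair shows this exact change, but compounds 2 and 3, which carry two chloro groups on their core, sit far weaker than compound 1. A step of moderate size toward weaker growth inhibition is therefore expected from compound 1 to compound 4, a 3.2-fold higher number from compound 1 to compound 4 (0.50 log units; beyond the scatter). Compound 4 is estimated at 6500 nM, within 2500 nM to 16000 nM.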

Compound 4, concentration for 50% growth inhibition: 1580 nM
Beside the measured number, compound 4's estimate is 4.1-fold (0.61 log units) above it; measured number below the stated range.
By their numbers in this assay, from the lowest: compounds 4 and 1 (each within the scatter of the next); then compounds 2 and 3 (each within the scatter of the next).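

In this assay, chloro in place of hydrogen on an aromatic carbon, between two ring nitrogen atoms, gives a 1.3-fold lower number from compound 1 to compound 4 (0.11 log units; within the scatter), so compound 1 and compound 4 cannot be told apart. Among the compounds shown here, this position therefore takes a chloro with no shift in growth inhibition beyond the scatter, which the earlier compounds could not show. Nothing available explains this tolerance. The compounds shown leave open whether the same position would also tolerate an amine or a methoxy group in place of the chloro.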